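The source may report more compounds than this note shows. Statements on the series, on what has been measured and on what is new or still open speak of the compounds shown alone.

Compound 1 `CC(=O)SCCC(CCCCC(=O)O)SC(C)=O`: 11%
Compound 2 `O=C(CCCCC1CCSS1)Nc1cccc(C(F)(F)F)c1`: 68.8%

In a functional assay on NCI-H460 cells (Homo sapiens) for inhibition, read by MTT assay, with a stated time of 24 h, tested at 100 ug/mL (a higher number here means more inhibition of growth at the concentration tested, a lower number less inhibition of growth), compound 2 gives 68.8% and holds the higher of the two numbers. Its gap to compound 1 at 11% lies beyond the usual scatter of such measurements.

Compound 3 `O=C(CCCCC1CCSS1)Nc1ccc([N+](=O)[O-])c(C(F)(F)F)c1` keeps all of compound 2 except for one place. It has nitro in place of hydrogen on an aromatic carbon, ortho to a trifluoromethyl group and para to a large group: nitro in place of hydrogen on an aromatic carbon.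

Going by the values given here, no measured pair shows what such a change does in this assay, so compound 2 at 68.8% is the only anchor for a forecast. No step beyond the scatter is expected, in either direction. The estimate corresponds to an expected a number 1.2 percentage points higher from compound 2 to compound 3 (within the scatter). The expected value for compound 3 is 70%, with an estimated range from 50% to 86%.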

Compound 3, percent growth inhibition at one concentration: 51.7%
Estimate against measurement, compound 3: 18.3 percentage points above; the measured number falls inside the stated range.
By their numbers in this assay, from the lowest: compound 1; then compound 3; then compound 2.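

In this assay, putting nitro in place of hydrogen on the aromatic ring gives a number 17.1 percentage points lower from compound 2 to compound 3 (beyond the scatter). Going by these compounds alone, this is the first measured change at a single place, and it shows that the position ortho to a trifluoromethyl group and para to a large group does not tolerate every group without loss, although compound 3 still reaches 51.7%. Nothing measured here explains why the number falls.

This single step cannot show whether the loss is specific to nitro, since an amine, a nitrile or a methoxy group at the same position could give a different number. It also leaves open whether nitro would lower the number in the same way elsewhere on the ring.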